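Adding a second chloro to the benzyl ring of compound 3

The compounds below may be only part of what the source reports. "The series", "measured", "known", "first", "only" and "open" are said of these compounds alone.

Measured so far, all in an assay on CHO cells for binding affinity to corticotropin-releasing factor receptor 1 (Homo sapiens); on this read-out lower numbers stand for stronger inhibition and higher numbers for weaker inhibition:
compound 1, `CCN(Cc1ccccc1C)c1cc(C)nc2c(-c3cnc(N(C)C)cc3C)c(C)nn12`: 2.4 nM
compound 2, `CCN(Cc1ccccc1F)c1cc(C)nc2c(-c3cnc(N(C)C)cc3C)c(C)nn12`: 3.4 nM
compound 3, `CCN(Cc1ccc(Cl)cc1)c1cc(C)nc2c(-c3cnc(N(C)C)cc3C)c(C)nn12`: 1.3 nM

Of the three numbers shown, compound 3 gives the lowest, though one of its two gaps (a 1.8-fold lower number from compound 1 to compound 3 (0.27 log units; within the scatter)) is within the scatter; only the other (a 2.6-fold lower number from compound 2 to compound 3 (0.42 log units; beyond the scatter)) goes beyond it. Compound 4, `CCN(Cc1ccc(Cl)c(Cl)c1)c1cc(C)nc2c(-c3cnc(N(C)C)cc3C)c(C)nn12`, differs from compound 3 by chloro in place of hydrogen on an aromatic carbon. For the measured compounds named here, no measured pair adds a group to a benzyl ring that already carries one; the closest guides are the swaps of the whole benzyl substituent, a 1.8-fold lower number from compound 1 to compound 3 (0.27 log units; within the scatter) and a 2.6-fold lower number from compound 2 to compound 3 (0.42 log units; beyond the scatter), and the exchange a 1.4-fold higher number from compound 1 to compound 2 (0.15 log units; within the scatter), all of which moved this assay by little. The shared core and the rest of the molecule stay unchanged. On that basis the step to compound 4 is expected to be small, with no clear direction beyond the scatter. Compound 4 is therefore estimated at about 1.5 nM, with a range from 0.6 nM to 4 nM. That estimate corresponds to an expected step of a 1.2-fold higher number from compound 3 to compound 4 (0.06 log units; within the scatter), within the scatter.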

Compound 4, inhibition constant: 2.5 nM
Estimate against measurement, compound 4: 1.7-fold (0.22 log units) below; the measured number falls inside the stated range.
By their numbers in this assay, from the lowest: compounds 3, 1, 4 and 2 (each within the scatter of the next, the first and the last beyond it).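

In this assay, for the compounds shown here, this is the first measured case of a group added to a benzyl ring that already carries one, and the change from 4-chlorobenzyl to 3,4-dichlorobenzyl gives a 1.9-fold higher number from compound 3 to compound 4 (0.28 log units; within the scatter), so a chloro ortho to a chloro group leaves the number within the scatter of that of the singly substituted ring. The same holds against the two ortho-free-of-chloro benzyl groups measured earlier, with a 1.4-fold lower number from compound 2 to compound 4 (0.13 log units; within the scatter) and a 1.0-fold higher number from compound 1 to compound 4 (0.02 log units; within the scatter). Compound 4 therefore lies within the scatter of compound 1, compound 2 and compound 3 alike, even though the gap between the last two, a 2.6-fold lower number from compound 2 to compound 3 (0.42 log units; beyond the scatter), goes beyond it, so the second chloro does not separate the dichlorinated compound from any of the others.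

Nothing at hand explains why this ring accepts the second chloro with so little movement in the number. Still open, on these data alone, is whether the same place on the ring would respond as mildly to something other than chloro, such as a methoxy group, an amine or a carboxylic acid, whose steps in this assay cannot be inferred from these four compounds.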